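A few compounds are considered here, and "the series" means these few. Any claim that something is new, unique, unknown or untested is made for them only; others in the source may bear on it.

Measured in an ADME assay on Caco-2 cells (Homo sapiens) for permeability, read by LC-MS, in the apical to basolateral direction, with a stated time of 60 min, at pH 6.5; a higher number here means that the compound crosses the layer faster, a lower number that the compound crosses the layer more slowly:
- compound 1 `CC(C)(C)OC[C@@H](O)C(=O)N1[C@H](C(=O)NCc2cc(Cl)ccc2-n2cnnn2)C[C@@H]2C[C@@H]21`: 4.5 10^-6 cm/s
- compound 2 `CC(C)(C)[C@@H](O)C(=O)N1C[S+]([O-])C[C@H]1C(=O)NCc1cc(Cl)ccc1-n1cnnn1`: 0.15 10^-6 cm/s
- compound 3 `O=C(NCc1cc(Cl)ccc1-n1cnnn1)[C@@H]1[C@@H]2C[C@@H]2CN1C(=O)[C@H](O)c1ccccc1`: 2.2 10^-6 cm/s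

Compound 1 stands highest of these three, with compound 3 and compound 2 lower by margins beyond the usual scatter. The next candidate, compound 4 `O=C(NCc1cc(Cl)ccc1-n1cnnn1)[C@@H]1C[C@@H]2C[C@@H]2N1C(=O)[C@H](O)c1ccccc1`, keeps the core of compound 1 but changes one group: phenyl in place of (tert-butoxy)methyl on a saturated chain carbon bound to a carbonyl carbon and an oxygen on a saturated carbon. In words, this is phenyl in place of (tert-butoxy)methyl on a saturated chain carbon bound to a carbonyl carbon and an oxygen on a saturated carbon.

Within the data shown here, no measured pair here differs in only one place, so the size of this change in this assay has no direct precedent. The nearest guide is compound 3, which also carries phenyl at that carbon, though on a different core, and gives 2.2 10^-6 cm/s. That value suggests a modest fall from compound 1, perhaps not clearing the scatter. The estimated change, a 1.7-fold lower number from compound 1 to compound 4 (0.24 log units; within the scatter), is therefore small and downward. For compound 4, the expected value is 2.6 10^-6 cm/s, with an estimated range from 1 10^-6 cm/s to 6 10^-6 cm/s.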

Compound 4, apparent permeability: 8 10^-6 cm/s
Compound 4: middle estimate off by 3.1-fold (0.49 log units), on the low side; measured number above the stated range.
By their numbers in this assay, from the lowest: compound 2; then compound 3; then compounds 1 and 4 (each within the scatter of the next).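

Among these compounds, on the core of compound 1, this assay gives the first direct reading of this change: phenyl in place of (tert-butoxy)methyl on a saturated chain carbon bound to a carbonyl carbon and an oxygen on a saturated carbon gives a 1.8-fold higher number from compound 1 to compound 4 (0.25 log units; within the scatter). At this position, then, a flexible open chain containing an ether oxygen and an aromatic ring of carbon only, each with 6 heavy atoms, cannot be told apart by this measurement. Nothing measured here explains why the two groups give such similar numbers.

As far as these compounds go, whether an amine, a carboxylic acid or a longer chain on this carbon would also stay within the scatter of compound 1 remains open. So does whether this exchange would give a similarly small step on a different core.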